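A few compounds are considered here, and "the series" means these few. Any claim that something is new, unique, unknown or untested is made for them only; others in the source may bear on it.

For the measured compounds named here, in a functional assay on L1210 cells (Mus musculus) for inhibition (a higher number here means a weaker inhibitor, a lower number a stronger inhibitor), only two compounds have numbers so far. Compound 1 (`O=C(CN(Cc1ccccc1)NC(=O)CBr)NNC(=O)OCc1ccccc1`) gives 600 nM and compound 2 (`CC(C)CN(CC(=O)NN(Cc1ccccc1)c1cnccn1)NC(=O)CBr`) gives 24100 nM as the higher of the two numbers. That places compound 2 as the weaker inhibitor of the pair, by a gap beyond the scatter. Compound 3 (`CC(C)CN(CC(=O)NN(Cc1ccccc1)c1cnccn1)NC(=O)Cc1cccc(Br)c1`) keeps the core of compound 2 and alters one group: 3-bromophenyl in place of bromo on a saturated chain carbon bound to a carbonyl carbon with 3-bromophenyl in place of bromo on a saturated chain carbon bound to a carbonyl carbon. Going by the values given here, no measured pair in this assay shows this change, so the expectation is loose. A moderate move towards a higher number is expected, though a result within the scatter of compound 2 would not surprise. The estimate means a 1.9-fold higher number from compound 2 to compound 3 (0.27 log units; within the scatter) as the expected change. Compound 3 is estimated at 45000 nM with an expected range from 12000 nM to 150000 nM in this measurement.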

Compound 3, half-maximal inhibitory concentration: 45000 nM
For compound 3 middle estimate and measured number coincide at the digits printed, within the range that was stated.
By their numbers in this assay, from the lowest: compound 1; then compounds 2 and 3 (each within the scatter of the next).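

In this assay, for the compounds shown here, this is the first step read at this position, on a saturated chain carbon bound to a carbonyl carbon: 3-bromophenyl in place of bromo gives a 1.9-fold higher number from compound 2 to compound 3 (0.27 log units; within the scatter). Bromomethyl can therefore give way to 3-bromobenzyl, which brings in one six-membered aromatic ring of carbon only, without a step beyond the scatter in this assay. Nothing measured here bears on this result.

The compounds shown leave open whether a plain benzyl group, without the bromine, or an amine or a carboxylic acid at this place would read any differently from compound 2. They also leave open whether a longer chain carrying the bromo group would stay within the scatter of compound 2.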